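Hexyl for tert-butyl at the para position of compound 2

The compounds below may be only part of what the source reports. "The series", "measured", "known", "first", "only" and "open" are said of these compounds alone.

In an assay on mitochondria from L6 cells (Rattus norvegicus) for activation, with a stated time of 90 min (a higher number here means that more compound is needed for the effect, a lower number that less compound is needed), compound 1 `Oc1nc2nonc2nc1Nc1ccc(OCC(F)(F)F)cc1` gives 42300 nM. Compound 2 `CC(C)(C)c1ccc(Nc2nc3nonc3nc2O)cc1` gives 3900 nM, the lowest of the two numbers measured; its nearest neighbour is compound 1, with the step of an 11-fold lower number from compound 1 to compound 2 (1.04 log units; beyond the scatter). Compound 3 `CCCCCCc1ccc(Nc2nc3nonc3nc2O)cc1` differs from compound 2 only as follows: hexyl in place of tert-butyl on an aromatic carbon. Among the measured compounds shown here, no measured step replaces one alkyl chain with another, so the step from compound 1 to compound 2 bears only loosely, being a different change. A step of a 1.1-fold lower number from compound 2 to compound 3 (0.05 log units; within the scatter) is therefore expected, with no clear direction beyond the scatter. Compound 3 is estimated at 3500 nM, within 900 nM to 14000 nM.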

Compound 3, half-maximal effective concentration: 4700 nM
Beside the measured number, compound 3's estimate is 1.3-fold (0.13 log units) below it; measured number inside the range.
By their numbers in this assay, from the lowest: compounds 2 and 3 (each within the scatter of the next); then compound 1.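

In this assay, hexyl and tert-butyl on this aromatic carbon cannot be told apart (a 1.2-fold higher number from compound 2 to compound 3 (0.08 log units; within the scatter)), so here a hexyl chain serves as well as tert-butyl. The step away from 2,2,2-trifluoroethoxy (a 9.0-fold lower number from compound 1 to compound 3 (0.95 log units; beyond the scatter)) shows that the lower number of compound 2 is not confined to tert-butyl but is shared by both alkyl groups shown. No evidence on hand accounts for either step. Open, from the compounds shown here alone, is whether a longer chain, such as decyl, keeps the number in this range, and how an amine or a carboxylic acid at this position would compare.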